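From Phenyl to 2-Hydroxyethyl on a Saturated Ring Carbon

This account rests on a few compounds, and the source may have more. Where it says the series, first, only, none or still open, it means among the compounds named here.

Of the compounds shown here, three built on one shared core have been tested in a functional assay on DLD-1 cells (Homo sapiens) for antiproliferative activity, read by CellTiter-Glo, with a stated time of 72 h; a lower number here means a stronger inhibitor, a higher number a weaker inhibitor. In this assay compound 1 `Cc1cc(C)c(S(=O)(=O)N2CCC(N3CCC(C)CC3)CC2)c(C)c1` gives 0.03 nM. Compound 2 `Cc1noc(C)c1S(=O)(=O)N1CCC(N2CCC(C)CC2)CC1` gives in this assay only a limit of the assay, > 5000 nM, and that is the limit of > 5000 nM in this assay, at which 1 of the 3 values shown sits. In this assay, within the data shown here, compound 3 `Cc1cc(C)c(S(=O)(=O)N2CCC(N3CCC(c4ccccc4)CC3)CC2)c(C)c1` gives 865 nM, the highest of the two numbers reported, and it is reached from compound 1 through the step of a 29000-fold higher number from compound 1 to compound 3 (4.46 log units; beyond the scatter), the single measured change on the saturated ring carbon that bears the large group.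

Compound 4 `Cc1cc(C)c(S(=O)(=O)N2CCC(N3CCC(CCO)CC3)CC2)c(C)c1` has not yet been measured in this assay. It differs from compound 3 in one place: 2-hydroxyethyl in place of phenyl on a saturated ring carbon. Among the measured compounds shown here, only the step from compound 1 to compound 3 bears on this change, and it was large; the move to compound 4 takes away the phenyl that accompanied that rise, yet it does not restore the methyl of compound 1, so the outcome is placed between the two measured points. For compound 4 the expected step is a 17-fold lower number from compound 3 to compound 4 (1.24 log units; beyond the scatter), a lower number than compound 3. Compound 4 is therefore estimated at 50 nM in this assay, within a range from 1 nM to 2500 nM.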

Compound 4, half-maximal inhibitory concentration: 19 nM
The estimate for compound 4 lay 2.6-fold (0.42 log units) above the measured number; the measured number falls inside the stated range.
By their numbers in this assay, from the lowest: compound 1; then compound 4; then compound 3. At a limit, above all of these: compound 2.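

The step of a 46-fold lower number from compound 3 to compound 4 (1.66 log units; beyond the scatter) shows that in this assay the loss seen with phenyl on this saturated ring carbon is not fixed for every group larger than methyl, since 2-hydroxyethyl, with no ring and with one oxygen, recovers a large part of it. Among these compounds, the recovery is only partial, as the step of a 630-fold higher number from compound 1 to compound 4 (2.80 log units; beyond the scatter) shows, so the three groups now tested at this position, methyl, 2-hydroxyethyl and phenyl, give three clearly separated results on the shared core, a graded response that the single earlier step could not reveal. The data given here hold no measurement that bears on either step.

The change from phenyl to 2-hydroxyethyl alters the ring, the atom count and the oxygen all at once, so the compounds shown cannot say which of these matters, and a plain ethyl or propyl chain on the same carbon would be needed to separate them. They also leave open how this position responds to a longer chain ending in hydroxyl, or to a chain ending in an amine or a carboxylic acid.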